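A single ring swap on the carbonyl carbon, before measurement

The compounds below may be only part of what the source reports. "The series", "measured", "known", "first", "only" and "open" are said of these compounds alone.

Compound 1, `COc1cc(-c2cc(/C=C/C(=O)c3ccc(N)cc3)[nH]n2)cc(OC)c1OC`, in a functional assay on TK-10 cells (Homo sapiens) for cytotoxicity, read by sulforhodamine B assay, with a stated time of 48 h, tested at 100 uM (on this read-out higher numbers stand for a weaker effect at the one concentration tested and lower numbers for a stronger effect), gives -81%.
Compound 2, `COc1ccc(C(=O)/C=C/c2cc(-c3cc(OC)c(OC)c(OC)c3)n[nH]2)cc1`, in this assay gives -20%.

Compound 2 stands highest of the two numbers in this assay, which on this read-out means the weaker effect, and its nearest neighbour is compound 1, separated by a change beyond the scatter. That single measured step, a number 61 percentage points higher from compound 1 to compound 2 (beyond the scatter), came from placing methoxy where amino sat on an aromatic carbon.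

Compound 3, `COc1cc(-c2cc(/C=C/C(=O)c3ccc(F)c(F)c3)[nH]n2)cc(OC)c1OC`, differs from compound 2 in one place: 3,4-difluorophenyl in place of 4-methoxyphenyl on a carbonyl carbon. For the measured compounds named here, the only measured step concerns a different exchange on that same ring, so it does not speak directly to what fluorine in place of methoxy will do; it shows only that altering this ring can move the number a long way. Going by the values given here, with no step that bears on the change itself, the expectation for this assay is a modest move, more likely toward a stronger effect, with the step of a number 15 percentage points lower from compound 2 to compound 3 (beyond the scatter), and compound 3 is estimated at -35%, within -75% to 5%.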

Compound 3, a percentage reported as activity, at one concentration (the size of the read-out at that concentration, not a potency): -37%
Estimate against measurement, compound 3: 2 percentage points above; the range from low to high includes it.
By their numbers in this assay, from the lowest: compound 1; then compound 3; then compound 2.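

In this assay, putting 3,4-difluorophenyl in place of 4-methoxyphenyl on the carbonyl carbon gives a number 17 percentage points lower from compound 2 to compound 3 (beyond the scatter) and so a stronger effect, which shows that a group other than 4-aminophenyl can also strengthen the effect from this position. The same ring falls well short of the amino compound, with a number 44 percentage points higher from compound 1 to compound 3 (beyond the scatter) on the same read-out, so the three rings now form a graded series with 4-aminophenyl strongest, 3,4-difluorophenyl in the middle and 4-methoxyphenyl weakest, rather than a simple split into one active ring and the rest. Nothing available explains why the rings fall in this order.

The compounds shown leave open whether both fluorines are needed, which a 4-fluorophenyl or 3-fluorophenyl ring would test, and how much any substituent contributes at all compared with a plain phenyl ring. They also leave open whether the strong effect of compound 1 depends on the free amino group specifically, a question that a 4-hydroxyphenyl or 4-(dimethylamino)phenyl ring in the same place could help to answer.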